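The source may report more compounds than this note shows. Statements on the series, on what has been measured and on what is new or still open speak of the compounds shown alone.

Compound 1 `COc1ccc([C@H]2CC(C)(O)[C@@H]3CC[C@@H](C)C[C@H]3O2)cc1OC` was tested in an ADME assay on MDCK cells (Canis lupus familiaris) for cytotoxicity, read by MTT assay, with a stated time of 48 h; on this read-out lower numbers stand for higher toxicity in this test and higher numbers for lower toxicity in this test. For compound 1 the result is a limit of the assay rather than a number, > 937000 nM. Compound 2 `COc1ccc([C@H]2CC(C)(O)[C@@H]3CC[C@@H](C)C[C@H]3O2)cc1O` differs from compound 1 in one place, (hydrogen in place of methyl on an oxygen on an aromatic ring). In this assay compound 2 gives 738000 nM. The change brought an at least 1.2-fold lower number from compound 1 to compound 2 (0.10 log units; that floor lies within the scatter), and the floor of that step rests on (the limit of > 937000 nM in this assay, at which 1 of the 3 values shown sits).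

Compound 3 `COc1ccc([C@H]2CC(C)(F)[C@@H]3CC[C@@H](C)C[C@H]3O2)cc1` carries a different core; how its core differs from the core of compound 1 is not broken down here. In this assay compound 3 gives 171000 nM. Compound 3 stands lowest of the two numbers reported, and its gap to compound 2 lies beyond the usual scatter, so compound 3 is the more toxic of these two in this test.

Compound 4 `C[C@@H]1CC[C@@H]2[C@@H](C1)O[C@@H](c1ccc(O)cc1)CC2(C)F` has not yet been measured. It differs from compound 3 by hydrogen in place of methyl on an oxygen on an aromatic ring, the same change that separates compound 1 from compound 2, at the same place with the same neighbour. That earlier step gave only a floor within the scatter, so little movement is expected here. Compound 4 is therefore expected to shift from compound 3 by a 1.1-fold lower number from compound 3 to compound 4 (0.06 log units; within the scatter). Compound 4 is estimated at 150000 nM, with the likely range running from 60000 nM to 400000 nM.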

Compound 4, half-maximal cytotoxic concentration: 95000 nM
Compound 4: the middle estimate sits 1.6-fold (0.20 log units) above what was measured; the range from low to high includes it.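

In this assay, hydrogen in place of methyl on an oxygen on an aromatic ring gave a 1.8-fold lower number from compound 3 to compound 4 (0.26 log units; within the scatter), so this pair cannot be told apart in this test. Set beside the earlier case, the change shows no step beyond the scatter on either core, and the two results can be compared only this far: the same change on two cores in this assay, an at least 1.2-fold lower number (0.10 log units; that floor lies within the scatter) from compound 1 to compound 2 and a 1.8-fold lower number (0.26 log units; within the scatter) from compound 3 to compound 4; the limit leaves it open whether they differ. The comparison therefore does not show that the change carries over with the same size, since the earlier step is only a floor, and it rests on a limit of the assay rather than a number: the limit of > 937000 nM in this assay, at which 1 of the 4 values shown sits.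

The compounds shown hold only methoxy and hydroxy groups on the aromatic ring, so they leave open how an amine, a carboxylic acid or a longer chain on that oxygen, such as ethoxy, would read in this assay. They also leave open which part of the difference between the two cores matters in this test, since no pair shown differs in a single place there, and whether the change would give a step beyond the scatter on a third core.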